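Phenyl in place of chloro on compound 2

This account rests on a few compounds, and the source may have more. Where it says the series, first, only, none or still open, it means among the compounds named here.

Measured in a functional assay on HL-60 cells (Homo sapiens), read by colorimetric assay, with a stated time of 24 h; a higher number here means a weaker inhibitor, a lower number a stronger inhibitor:
- Compound 1 `CNc1ncnc2c1ncn2[C@@H]1O[C@H]([C@H](O)CO)[C@@H](O)[C@H]1O`: > 100000 nM (a limit of the assay, not a number)
- Compound 2 `CC(=O)OC[C@@H](OC(C)=O)[C@H]1O[C@@H](n2cnc3c(Cl)ncnc32)[C@H](OC(C)=O)[C@@H]1OC(C)=O`: 79300 nM

For the measured compounds named here, compound 2, at 79300 nM, gives the only actual number so far. Compound 3 `CC(=O)OC[C@@H](OC(C)=O)[C@H]1O[C@@H](n2cnc3c(-c4ccccc4)ncnc32)[C@H](OC(C)=O)[C@@H]1OC(C)=O` carries phenyl in place of chloro on an aromatic carbon. Going by the values given here, no measured step between compounds differing in one place is available to guide the size of this change, so the expectation is tentative. A modest move towards stronger inhibition in this assay is expected, and the estimated step of a 2.3-fold lower number from compound 2 to compound 3 (0.36 log units; beyond the scatter) reflects that. For compound 3 the estimate is 35000 nM, with an expected range of 10000 nM to 100000 nM.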

Compound 3, half-maximal inhibitory concentration: > 100000 nM
Compound 3 gave a limit, no number (the forecaster's own chance of this, stated with the estimate: 20%); middle value at least 2.8-fold (0.45 log units) from the limit.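

In this assay compound 3 gives a limit and not a number. Phenyl in place of chloro on this aromatic carbon can therefore be read only as an at least 1.2-fold higher number from compound 2 to compound 3 (0.10 log units; that floor lies within the scatter) and this floor lies within the scatter. The larger aromatic group brings no sign of stronger inhibition, and the true size of any loss stays hidden at the top of the measurable range: the limit of > 100000 nM in this assay, at which 2 of the 3 values shown sit.

Going by these compounds, whether an amine or a methoxy group on this same aromatic carbon would give a lower number remains open.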